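Swapping the aryl ether headgroup in an ovarian cancer cell assay

This account rests on a few compounds, and the source may have more. Where it says the series, first, only, none or still open, it means among the compounds named here.

Measured so far:
compound 1, `c1ccc(COc2ccc(OCCOCCOC3CCCC3)cc2)cc1`: > 100000 nM
compound 2, `COc1ccc(COc2ccc(OCCOCCNC3CCCC3)cc2)cc1`: 15700 nM
compound 3, `c1ccc(COc2ccc(OCCOCCNc3ccccc3)cc2)cc1`: > 100000 nM

Three compounds share a core in which two ether-linked chains hang from a central aromatic ring. In a functional assay on SK-OV-3 cells (Homo sapiens) for inhibition, read by CCK-8 assay, with a stated time of 70 h (a higher number here means a weaker inhibitor, a lower number a stronger inhibitor), compound 1 reaches only the limit of the measurement, > 100000 nM. Compound 3 likewise gives only a limit, > 100000 nM. The step that the two limits leave unreadable from compound 1 to compound 3 therefore cannot be read, because both of its ends sit at the limit of > 100000 nM in this assay, at which 2 of the 3 values shown sit. Among the compounds with values here, compound 2 is the one compound with a real number, 15700 nM, and so it is the only anchor for any comparison.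

Compound 4, `O=[N+]([O-])c1cccc(COc2ccc(OCCOCCNC3CCCC3)cc2)c1`, has not been measured. It differs from compound 2 in one place: 3-nitrophenyl in place of 4-methoxyphenyl on a saturated chain carbon bound to an oxygen on an aromatic ring. Within the data shown here, no measured step touches that part of the molecule; the one computed step concerns the other chain end, and its size is unreadable. There is thus no basis for expecting a move in either direction beyond the scatter.

Compound 4 is expected to give about 20000 nM in this assay, with a range from 5000 nM to 80000 nM, which would mean an estimated step of a 1.3-fold higher number from compound 2 to compound 4 (0.11 log units; within the scatter).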

Compound 4, half-maximal inhibitory concentration: 15400 nM
For compound 4 the middle estimate is 1.3-fold (0.11 log units) above the measured one; the measured number falls inside the stated range.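

Within the data shown here, the step of a 1.0-fold lower number from compound 2 to compound 4 (0.01 log units; within the scatter) is the first readable comparison in this assay and the first that touches the aryl group on a saturated chain carbon bound to an oxygen on an aromatic ring. It shows that 3-nitrophenyl can stand in place of 4-methoxyphenyl with the two numbers remaining within the usual scatter of each other, even though the entering group brings nitrogen and a double bond outside the aromatic ring that the leaving group lacks. Nothing measured here explains why these two different groups give matching numbers, so no cause can be named.

Among these compounds, it remains open whether this position would tolerate a phenyl ring carrying a carboxylic acid or an amine, or a longer chain between this ring and the oxygen, as compound 2 and compound 4 test only one exchange of groups. At the other chain end, the step from the cyclopentyloxy group of compound 1 to the anilino group of compound 3 still cannot be read, and each of those two values is a limit rather than a number: the limit of > 100000 nM in this assay, at which 2 of the 4 values shown sit.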